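Selenium for sulfur on the shared core: growth inhibition notes

The source may hold more compounds than are shown below. What is called first, only, known or untested is meant among the compounds shown, and "the series" means these compounds.

In an ADME assay on 184B5 cells (Homo sapiens) for cytotoxicity, read by MTT assay, with a stated time of 72 h (on this read-out lower numbers stand for stronger inhibition of growth and higher numbers for weaker inhibition of growth), the measured compounds stand as follows:
compound 1 `COc1ccc(CNc2nc([Se]C)nc3ccccc23)cc1` gives 75600 nM
compound 2 `COc1ccc(CNc2nc(SC)nc3ccccc23)cc1` gives 85600 nM
compound 3 `CSc1ccc(CNc2nc(SC)nc3ccccc23)cc1` gives 22000 nM

From compound 2 to compound 1 the change is a group of 2 heavy atoms (1 carbon, 1 selenium; no ring) in place of a group of 2 heavy atoms (1 carbon, 1 sulfur; no ring), on an aromatic carbon; in this assay the step was a 1.1-fold lower number from compound 2 to compound 1 (0.05 log units; within the scatter). The cores of compound 2 and compound 3 differ by methylsulfanyl in place of methoxy on an aromatic carbon, a step of a 3.9-fold lower number from compound 2 to compound 3 (0.59 log units; beyond the scatter).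

Compound 4 `CSc1ccc(CNc2nc([Se]C)nc3ccccc23)cc1` is not yet measured. It differs from compound 3 by a group of 2 heavy atoms (1 carbon, 1 selenium; no ring) in place of a group of 2 heavy atoms (1 carbon, 1 sulfur; no ring), on an aromatic carbon, the same change at the same place as from compound 2 to compound 1. In this assay, among the compounds with values here, the step is therefore expected to be a 1.1-fold lower number from compound 3 to compound 4 (0.04 log units; within the scatter), resting on a 1.1-fold lower number from compound 2 to compound 1 (0.05 log units; within the scatter) as the only instance of this change. For compound 4 the estimate is 20000 nM. Repeats for compound 4 are expected mostly from 8000 nM to 50000 nM.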

Compound 4, concentration for 50% growth inhibition: 37100 nM
For compound 4 the middle estimate is 1.9-fold (0.27 log units) below the measured one; the range from low to high includes it.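

In this assay, selenium for sulfur on the shared core gives a 1.7-fold higher number from compound 3 to compound 4 (0.23 log units; within the scatter), and this step carries from one core to the other with no difference beyond the scatter: the same change on two cores in this assay, a 1.1-fold lower number (0.05 log units; within the scatter) from compound 2 to compound 1 and a 1.7-fold higher number (0.23 log units; within the scatter) from compound 3 to compound 4, 1.9-fold (0.28 log units) apart, within the scatter of two such steps. Methylsulfanyl in place of methoxy gives a 2.0-fold lower number from compound 1 to compound 4 (0.31 log units; beyond the scatter), and this change also carries across both cores: the same change on two cores in this assay, a 3.9-fold lower number (0.59 log units; beyond the scatter) from compound 2 to compound 3 and a 2.0-fold lower number (0.31 log units; beyond the scatter) from compound 1 to compound 4, 1.9-fold (0.28 log units) apart, within the scatter of two such steps. Two instances of each change show agreement within these four compounds only, and they do not establish that either change would transfer to other cores or to other assays.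

Still open, going by these compounds, is how an amine or a halogen in place of methoxy would read on either core. On these data alone, a longer chain in place of the methyl on sulfur or selenium also remains open.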